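Ester Swap on a Scaffold of Low Stability

The source may report more compounds than this note shows. Statements on the series, on what has been measured and on what is new or still open speak of the compounds shown alone.

Compound 2 `CCCCc1nc(C)c(CC(=O)OC(C)C)c(=O)n1Cc1ccc(-c2ccccc2-c2noc(=O)[nH]2)cc1` was tested in an ADME assay on microsomes from liver (Homo sapiens) for metabolic stability, with a stated time of 30 min (a lower number here means that less of the compound is left, a higher number that more of the compound is left), alongside compound 1 `CCCCCOC(=O)Cc1c(C(C)C)nc(CCCC)n(Cc2ccc(-c3ccccc3-c3noc(=O)[nH]3)cc2)c1=O`. In this assay compound 2 gives 17.5%, and compound 1 gives 10.6%; the two numbers lie within the scatter of each other, and both show little compound surviving. Compound 3 `CC#CCOC(=O)Cc1c(C)nc(CCCC)n(Cc2ccc(-c3ccccc3-c3noc(=O)[nH]3)cc2)c1=O` differs from compound 2 in one place: but-2-yn-1-yl in place of isopropyl on an oxygen next to a carbonyl group. Going by the values given here, no measured pair shows this change, and the step is expected to stay within the scatter, perhaps leaning slightly downward. Compound 3 is expected to give 14%, with a range from 5% to 30%. This amounts to an expected step of a number 3.5 percentage points lower from compound 2 to compound 3 (within the scatter).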

Compound 3, percent of the compound remaining: 32%
For compound 3 the middle estimate is 18 percentage points below the measured one; the whole stated range lies below it.
By their numbers in this assay, from the lowest: compounds 1 and 2 (each within the scatter of the next); then compound 3.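

Going by these compounds alone, with but-2-yn-1-yl in place of isopropyl on an oxygen next to a carbonyl group, this assay gives a number 14.5 percentage points higher from compound 2 to compound 3 (beyond the scatter) as the first single-place step in this set. It shows that this one group can move the amount of compound left by more than the usual scatter, with the rest of the structure unchanged. Nothing available explains why the number rises. The compounds shown leave open whether the triple bond or the extra carbon matters, a question that a butyl group on that oxygen could help answer. On these data alone, how a carboxylic acid in place of the ester would behave also remains open.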